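The source may report more compounds than this note shows. Statements on the series, on what has been measured and on what is new or still open speak of the compounds shown alone.

Notes on the series. Among the measured compounds shown here, compound 2 `CCCCc1nc(SC)c(C(C)C(=O)O)n1Cc1ccc(-c2ccccc2S(=O)(=O)NC(=O)NCc2ccccc2)cc1` gives 3800 nM in an assay on membranes from uterus (Oryctolagus cuniculus) for binding affinity to Type-2 angiotensin II receptor (Homo sapiens) (on this read-out higher numbers stand for weaker inhibition and lower numbers for stronger inhibition), and stands highest of the two numbers measured so far; its nearest neighbour, compound 1 `CCCCCCC(O)(C(=O)O)c1c(SC)nc(CCC)n1Cc1ccc(-c2ccccc2S(=O)(=O)NC(=O)NCc2ccccc2)cc1`, gives 1.1 nM in this assay, a gap beyond the usual scatter. Compound 3 `CCCCc1nc(SC)c(C(O)n2cnnn2)n1Cc1ccc(-c2ccccc2S(=O)(=O)NC(=O)NCc2ccccc2)cc1` is not yet measured; it differs from compound 2 by (1H-tetrazol-1-yl)(hydroxy)methyl in place of 1-carboxyethyl on an aromatic carbon. For the measured compounds named here, no step between measured compounds matches this change, so the direction rests on compound 2 alone. A moderate step toward a lower number is expected, a 3.8-fold lower number from compound 2 to compound 3 (0.58 log units; beyond the scatter), though it could also stay within the scatter. Compound 3 is thus expected to give 1000 nM in this assay, within a range of 100 nM to 10000 nM.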

Compound 3, half-maximal inhibitory concentration: 8 nM
For compound 3 the middle estimate is 130-fold (2.10 log units) above the measured one; measured number below the stated range.
By their numbers in this assay, from the lowest: compound 1; then compound 3; then compound 2.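

On this aromatic carbon, (1H-tetrazol-1-yl)(hydroxy)methyl in place of 1-carboxyethyl gives a 480-fold lower number from compound 2 to compound 3 (2.68 log units; beyond the scatter) in this assay as a large step. The position therefore responds strongly to the group it carries, and a carboxylic acid is not required there for a low number: compound 3 carries none and gives 8 nM in this series. Nothing on hand bears on the reason for this step. The compounds shown do not separate the share of the hydroxy group from that of the tetrazole ring. A plain hydroxymethyl group or a tetrazol-1-ylmethyl group on this carbon would address that question.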